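A few compounds are considered here, and "the series" means these few. Any claim that something is new, unique, unknown or untested is made for them only; others in the source may bear on it.

Measured compounds:
compound 1, `COc1cc(C(=O)O)ccc1OCCCCOc1ccc(C(=O)CC(C)(C)C)c(O)c1C`, gives 109%
compound 2, `Cc1c(OCCCCOc2ccc(C(=O)O)cc2Cl)ccc(C(=O)CC2CCCC2)c1O`, gives 27.4%
compound 3, `CCC(=O)c1ccc(OCCCCOc2ccc(F)c(C(=O)O)c2)c(C)c1O`, gives 18.4%

These three values come from an assay on HEK293 cells for positive allosteric modulation of metabotropic glutamate receptor 3 (Rattus norvegicus), read by thallium flux, with a stated time of 2.5 min; a lower number here means a smaller maximal response, a higher number a larger maximal response. Among them, compound 2 holds the second highest number. Its nearest neighbour is compound 3, whose value lies within the usual scatter of compound 2, so no order between these two can be claimed. Its furthest neighbour is compound 1, whose value lies well beyond the scatter above compound 2. For the measured compounds named here, no step between any pair of these measured compounds has been computed, so only the bare values are compared here.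

The unmeasured compound 4, `Cc1c(OCCCCOc2ccc(C(=O)O)cc2)ccc(C(=O)CC2CCCC2)c1O`, differs from compound 2 in one place: hydrogen in place of chloro on an aromatic carbon. The chloro sits on an aromatic carbon of a six-membered aromatic ring of carbon only, ortho to a large group and meta to a carboxy group, and is replaced by hydrogen.

Going by the values given here, nothing among the measured compounds isolates this change, so the direction is open. Compound 4 is expected to give roughly 40% in this assay, within 15% to 80%. The expected step of a number 12.6 percentage points higher from compound 2 to compound 4 (beyond the scatter) is therefore a modest rise that may not exceed the scatter.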

Compound 4, largest response reached (reported as percent of maximum), in percent of the reference or control that the assay uses: 26.7%
Beside the measured number, compound 4's estimate is 13.3 percentage points above it; the measured number falls inside the stated range.
By their numbers in this assay, from the lowest: compounds 3, 4 and 2 (each within the scatter of the next); then compound 1.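

In this assay, the step for hydrogen in place of chloro on this aromatic carbon, ortho to a large group and meta to a carboxy group, is a number 0.7 percentage points lower from compound 2 to compound 4 (within the scatter). For the compounds shown here, this is the first direct reading of this position, since the earlier compounds differed from one another in more than one place: going from 4-carboxy-2-chlorophenyl to 4-carboxyphenyl leaves the maximal response indistinguishable in this pair, so the chloro is not required for the level of response seen here. No supporting data bear on why the two compounds read alike.

The compounds shown leave open what a nitrile, a trifluoromethyl or an amine on this same carbon would give. They also leave open whether the chloro-to-hydrogen swap reads the same way when the cyclopentyl group on the ketone side is replaced by a longer chain.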